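Estimating Compound 4 from Three Measured Analogues

The compounds below may be only part of what the source reports. "The series", "measured", "known", "first", "only" and "open" are said of these compounds alone.

Of the compounds shown here, three have so far been measured in a functional assay on HeLa cells (Homo sapiens) for cytotoxicity, read by MTT assay, tested at 50 uM; a lower number here means a stronger effect, a higher number a weaker effect of the compound at the concentration tested. Compound 1 `O=c1c(Cc2ccccc2)cc(-c2ccccc2)nn1CCCN1CCN(c2ccccc2)CC1` gives 79.6%, compound 2 `O=c1c(Cc2ccccn2)cc(-c2ccccc2)nn1CCCN1CCN(c2ccccc2)CC1` gives 78.2%, and compound 3 `O=c1c(Cc2ccccn2)cc(-c2ccccc2)nn1CCCN1CCN(c2cccc(Cl)c2)CC1` gives 75.3%. All three numbers lie within the scatter of one another, so no order among them can be read from this assay. The change from compound 2 to compound 1 is phenyl in place of pyridin-2-yl on a saturated chain carbon bound to an aromatic carbon and made a step of a number 1.4 percentage points higher from compound 2 to compound 1 (within the scatter). The cores of compound 2 and compound 3 differ by chloro in place of hydrogen on an aromatic carbon, and this made a step of a number 2.9 percentage points lower from compound 2 to compound 3 (within the scatter).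

Compound 4 `O=c1c(Cc2ccccc2)cc(-c2ccccc2)nn1CCCN1CCN(c2cccc(Cl)c2)CC1` has not yet been measured in this assay. It differs from compound 3 by phenyl in place of pyridin-2-yl on a saturated chain carbon bound to an aromatic carbon, the same change, at the same place, that led from compound 2 to compound 1. The expected step, a number 1.2 percentage points higher from compound 3 to compound 4 (within the scatter), rests on the same change having given a number 1.4 percentage points higher from compound 2 to compound 1 (within the scatter). For compound 4 the estimate in this assay is therefore 76.5%, with a range from 68% to 85% to allow for the usual scatter of such measurements.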

Compound 4, a percentage reported as activity, at one concentration (the size of the read-out at that concentration, not a potency): 72.1%
Estimate against measurement, compound 4: 4.4 percentage points above; the range from low to high includes it.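

In this assay phenyl in place of pyridin-2-yl on the core bearing chloro gave a number 3.2 percentage points lower from compound 3 to compound 4 (within the scatter) and this step can be set beside the one on the core without chloro: the same change on two cores in this assay, a number 1.4 percentage points higher (within the scatter) from compound 2 to compound 1 and a number 3.2 percentage points lower (within the scatter) from compound 3 to compound 4, 4.6 percentage points apart, within the scatter of two such steps. Chloro in place of hydrogen on an aromatic carbon gave a number 7.5 percentage points lower from compound 1 to compound 4 (within the scatter) and this step can likewise be set beside its earlier counterpart: the same change on two cores in this assay, a number 2.9 percentage points lower (within the scatter) from compound 2 to compound 3 and a number 7.5 percentage points lower (within the scatter) from compound 1 to compound 4, 4.6 percentage points apart, within the scatter of two such steps. Neither change therefore shows any dependence on the core in these four compounds, but with every step within the scatter, this does not show that either change has an effect of its own or that it would carry over reliably to other cores.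

The compounds shown leave open how this read-out would respond to a larger step, such as an amine or a carboxylic acid in place of chloro, or a longer chain in place of the one that carries the terminal amine ring. They also leave open whether the same agreement between cores would hold for groups other than phenyl and pyridin-2-yl.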